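From (4-methylphenyl)sulfonyl to formyl on a shared core

This account rests on a few compounds, and the source may have more. Where it says the series, first, only, none or still open, it means among the compounds named here.

Measured in a functional assay on Bel-7402 cells (Homo sapiens) for antiproliferative activity, with a stated time of 48 h; a higher number here means a weaker inhibitor, a lower number a stronger inhibitor
Compound 1 `C=CCN1c2c(N)nc(N)nc2CCC1CN(C)c1ccc(C(=O)N[C@@H](CCC(=O)O)C(=O)O)cc1` at 61500 nM
Compound 2 `Cc1ccc(S(=O)(=O)N2c3c(N)nc(N)nc3CCC2CN(C)c2ccc(C(=O)N[C@@H](CCC(=O)O)C(=O)O)cc2)cc1` at 325 nM

Compound 2 stands at 325 nM as the lower of the two numbers. Compound 3 `CN(CC1CCc2nc(N)nc(N)c2N1C=O)c1ccc(C(=O)N[C@@H](CCC(=O)O)C(=O)O)cc1` differs from it by formyl in place of (4-methylphenyl)sulfonyl on a nitrogen on an aromatic ring in a ring. Among the compounds with values here, the one measured step at this nitrogen is a 190-fold lower number from compound 1 to compound 2 (2.28 log units; beyond the scatter) and it is large, so a sizeable change is expected here too, though no formyl compound has been measured. The expected change, toward a higher number, is a 6.2-fold higher number from compound 2 to compound 3 (0.79 log units; beyond the scatter) in this assay as estimated. Compound 3 is estimated at 2000 nM with an expected range from 150 nM to 30000 nM in this account.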

Compound 3, half-maximal inhibitory concentration: 65200 nM
Compound 3: the middle estimate sits 33-fold (1.51 log units) below what was measured, outside the stated range (above it).
By their numbers in this assay, from the lowest: compound 2; then compounds 1 and 3 (each within the scatter of the next).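

In this assay, formyl does not keep what (4-methylphenyl)sulfonyl gave at this nitrogen, with a 200-fold higher number from compound 2 to compound 3 (2.30 log units; beyond the scatter) as the step between them. Formyl and allyl do not separate, with a 1.1-fold higher number from compound 1 to compound 3 (0.03 log units; within the scatter) lying within the scatter, so among these three groups only (4-methylphenyl)sulfonyl stands apart. Nothing measured here accounts for this difference.

On these data alone, whether the sulfonyl or the aromatic ring carries the low number remains open. A methylsulfonyl group and a benzoyl group on this nitrogen would tell those two parts apart.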